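Chlorine Position on the Aryl Ring: Compound 3 Expected

The compounds below may be only part of what the source reports. "The series", "measured", "known", "first", "only" and "open" are said of these compounds alone.

Compound 2 `Clc1ccc(-c2nnc(SCCCN3CCN(c4ncccn4)CC3)[nH]2)cc1` is one of two measured members of this small series. In a functional assay on COLO 205 cells (Homo sapiens) for cytotoxicity, read by MTT assay, with a stated time of 24 h (a higher number here means a weaker inhibitor, a lower number a stronger inhibitor), compound 2 gives only a limit, > 300000 nM. Its one measured relative, compound 1 `Clc1ccc(-c2nnc(SCCCN3CCN(c4cccc(Cl)c4)CC3)[nH]2)cc1`, likewise returns only a limit in this assay, > 300000 nM. Within the data shown here, the single step that joins them, a step that the two limits leave unreadable from compound 1 to compound 2, cannot be read because of the limit of > 300000 nM in this assay, at which 2 of the 2 values shown sit. Compound 3 `Clc1cccc(-c2nnc(SCCCN3CCN(c4ncccn4)CC3)[nH]2)c1` has the same atoms as compound 2 joined differently: 3-chlorophenyl in place of 4-chlorophenyl on an aromatic carbon. Among the measured compounds shown here, no measured step bears directly on this change, and the one step that is known is itself unreadable, so the expectation rests on compound 2 alone. Compound 3 is expected to sit at the same limit, with the step of a number no higher from compound 2 to compound 3 (the limit leaves the size open) expected to show nothing beyond the scatter. The estimate for compound 3 in this assay is 300000 nM, ranging from 100000 nM to 1000000 nM, and most likely only a limit will again be reported.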

Compound 3, half-maximal inhibitory concentration: > 300000 nM
Compound 3: a limit, no number (the forecaster's own chance of this, stated with the estimate: 80%); the middle value sits exactly at the limit.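

In this assay no step can be read between compound 2 and compound 3, nor between compound 1 and compound 2, because each compound returns only a limit: the limit of > 300000 nM in this assay, at which 3 of the 3 values shown sit. The compounds shown leave open whether 3-chlorophenyl in place of 4-chlorophenyl changes the result in this assay at all.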